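The source may hold more compounds than are shown below. What is called first, only, known or untested is meant among the compounds shown, and "the series" means these compounds.

In a functional assay on SGC-7901 cells (Homo sapiens) for cytotoxicity, read by MTT assay, with a stated time of 48 h (a higher number here means a weaker inhibitor, a lower number a stronger inhibitor), compound 3 `O=c1ccoc2cc(OCc3cn(Cc4cccc([N+](=O)[O-])c4)nn3)ccc12` gives > 100000 nM, which is a limit of the assay and not a number. Compound 1 `O=c1ccoc2cc(OCc3cn(Cc4ccccc4Br)nn3)ccc12` gives > 100000 nM, likewise a limit. Compound 2 `O=c1ccoc2cc(OCc3cn(Cc4ccccc4Cl)nn3)ccc12` gives > 100000 nM, also a limit. Going by the values given here, the evidence the limit of > 100000 nM in this assay, at which 3 of the 3 values shown sit, says where every value so far sits. The steps a step that the two limits leave unreadable from compound 1 to compound 3 and a step that the two limits leave unreadable from compound 2 to compound 3 bear on the change at the saturated chain carbon bound to an aromatic nitrogen, and so does a step that the two limits leave unreadable from compound 1 to compound 2 for a halogen swap, yet none has a readable size. Compound 4 `O=c1ccoc2cc(OCc3cn(Cc4ccccc4F)nn3)ccc12` carries 2-fluorophenyl in place of 3-nitrophenyl on a saturated chain carbon bound to an aromatic nitrogen. With no readable step to lean on, no direction beyond the scatter can be set for this assay. Compound 4 is expected to give 100000 nM, between 30000 nM and 300000 nM, most probably again only a limit. The step of a number no higher from compound 3 to compound 4 (the limit leaves the size open) is the estimated outcome.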

Compound 4, half-maximal inhibitory concentration: > 100000 nM
Compound 4: a limit, no number (the forecaster's own chance of this, stated with the estimate: 85%); the middle value sits exactly at the limit.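

Compound 4 ends at the same limit as compound 1, compound 2 and compound 3, so no step among them can be read: the limit of > 100000 nM in this assay, at which 4 of the 4 values shown sit.

The compounds shown leave open whether any of these swaps changes cytotoxicity at all.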